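The source may hold more compounds than are shown below. What is called first, only, known or untested is meant among the compounds shown, and "the series" means these compounds.

Compound 1, `CC(C)=CCC/C(C)=C/CC/C(C)=C/CC[C@@H]1[C@@]2(C)CCC(=O)C(C)(C)[C@@H]2CC[C@@]1(C)O`: 12000 nM
Compound 2, `CC(C)=CCC/C(C)=C/CC/C(C)=C/CC[C@@H]1[C@@]2(C)CC/C(=N\OCc3cn(-c4ccccc4C#N)nn3)C(C)(C)[C@@H]2CC[C@@]1(C)O`: 20000 nM

In a functional assay on A549 cells (Homo sapiens) for cytotoxicity, read by MTT assay, with a stated time of 48 h (a lower number here means a stronger inhibitor, a higher number a weaker inhibitor), compound 2 stands at the larger of the two numbers, but its gap to compound 1 lies within the scatter, so the two cannot be ordered. Compound 3, `CC(C)=CCC/C(C)=C/CC/C(C)=C/CC[C@@H]1[C@@]2(C)CC/C(=N\OCc3cn(-c4c(Cl)cc([N+](=O)[O-])cc4Cl)nn3)C(C)(C)[C@@H]2CC[C@@]1(C)O`, differs from compound 2 by 2,6-dichloro-4-nitrophenyl in place of 2-cyanophenyl on an aromatic nitrogen. Among the measured compounds shown here, no step between measured compounds is available to guide the change. The step from a 1.1-fold lower number from compound 2 to compound 3 (0.05 log units; within the scatter) is expected to be small, probably not beyond the scatter. Compound 3 is therefore estimated at 18000 nM in this assay, with a range of 8000 nM to 45000 nM.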

Compound 3, half-maximal inhibitory concentration: 11200 nM
Beside the measured number, compound 3's estimate is 1.6-fold (0.21 log units) above it; the range from low to high includes it.
By their numbers in this assay, from the lowest: compounds 3, 1 and 2 (each within the scatter of the next).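

Placing 2,6-dichloro-4-nitrophenyl in place of 2-cyanophenyl on the aromatic nitrogen gives a 1.8-fold lower number from compound 2 to compound 3 (0.25 log units; within the scatter) in this assay. This position therefore carries a second, larger substituted phenyl group with no change that can be told from the scatter. Nothing available explains this result. As far as these compounds go, whether any group on this nitrogen can move the number beyond the scatter stays open. A phenyl bearing a carboxylic acid or an amine, or a plain alkyl chain in its place, could test this.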